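Swapping 2-chlorophenyl for 3-methoxyphenyl: a small step expected

This account rests on a few compounds, and the source may have more. Where it says the series, first, only, none or still open, it means among the compounds named here.

Measured so far in a functional assay on the whole organism (strain Kunming) with Mus musculus as the target, with a stated time of 0.5 h; on this read-out higher numbers stand for an effect only at larger amounts of compound and lower numbers for an effect already at smaller amounts
Compound 1 `COc1cc(OC)c(OC)cc1/C=C/COC(=O)/C=C/c1ccc(Br)cc1` gives > 692 umol/kg as a limit of the assay
Compound 2 `COc1cc(OC)c(OC)cc1/C=C/COC(=O)/C=C/c1cccc(Br)c1` gives 497 umol/kg
Compound 3 `COc1cc(OC)c(OC)cc1/C=C/COC(=O)/C=C/c1ccccc1Cl` gives 639 umol/kg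

Compound 3 stands within the usual scatter of compound 2 (a 1.3-fold higher number from compound 2 to compound 3 (0.11 log units; within the scatter)), so the two cannot be told apart. Compound 4 (`COc1cccc(/C=C/C(=O)OC/C=C/c2cc(OC)c(OC)cc2OC)c1`) carries 3-methoxyphenyl in place of 2-chlorophenyl on a double-bonded chain carbon bound to a double-bonded chain carbon. Within the data shown here, no measured compound carries 3-methoxyphenyl, so only the other swaps at this place bear on the change. These swaps (an at least 1.3-fold lower number from compound 1 to compound 2 (0.14 log units; that floor lies within the scatter)) and (an at least 1.0-fold lower number from compound 1 to compound 3 (0.03 log units; that floor lies within the scatter)) also stay within the scatter. In this assay no step beyond the scatter is therefore expected for this swap. The expected change is small (a 1.1-fold lower number from compound 3 to compound 4 (0.06 log units; within the scatter)) and lies within the scatter. For compound 4 the estimate is 560 umol/kg (expected range 300 umol/kg to 900 umol/kg).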

Compound 4, dose for half-maximal effect: 647 umol/kg
For compound 4 the middle estimate is 1.2-fold (0.06 log units) below the measured one, and the stated range covers the measured number.
By their numbers in this assay, from the lowest: compounds 2, 3 and 4 (each within the scatter of the next). At a limit, above all of these: compound 1.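

On a double-bonded chain carbon bound to a double-bonded chain carbon, 3-methoxyphenyl is the first group shown without a halogen, yet in this assay it cannot be told apart from 2-chlorophenyl (a 1.0-fold higher number from compound 3 to compound 4 (0.01 log units; within the scatter)). Methoxy in place of bromo on an aromatic carbon also changes nothing that can be told apart (a 1.3-fold higher number from compound 2 to compound 4 (0.11 log units; within the scatter)). From the compounds shown here alone, compound 1 stands at a limit, so its step gives only a floor (an at least 1.0-fold lower number from compound 1 to compound 4 (0.02 log units; that floor lies within the scatter)) and its true distance stays unknown: the limit of > 692 umol/kg in this assay, at which 1 of the 4 values shown sits.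

Going by these compounds, whether an amine or a carboxylic acid on this aromatic ring would give a step beyond the scatter remains open.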